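This account rests on a few compounds, and the source may have more. Where it says the series, first, only, none or still open, it means among the compounds named here.

Measured compounds:
compound 1 `Cc1cccc(-c2c(C)nn(-c3nc(-c4ccc(Cl)c(Cl)c4)c(SC(C)C)s3)c2C(=O)O)c1` — 17000 nM
compound 2 `COc1cc(Cl)cc(-c2c(C)nn(-c3nc(-c4ccc(Cl)c(Cl)c4)c(SC(C)C)s3)c2C(=O)O)c1` — 760 nM

In a functional assay on BJAB cells (Homo sapiens) for antiproliferative activity, with a stated time of 4 days (on this read-out higher numbers stand for an effect only at larger amounts of compound and lower numbers for an effect already at smaller amounts), compound 2 gives the lowest of the two numbers; compound 1 gives 17000 nM, and the step of a 22-fold lower number from compound 1 to compound 2 (1.35 log units; beyond the scatter) shows that the aryl group on the shared core can move the read-out strongly. Compound 3 `CC(=O)Nc1ccc(-c2c(C)nn(-c3nc(-c4ccc(Cl)c(Cl)c4)c(SC(C)C)s3)c2C(=O)O)cc1` differs from compound 2 by 4-acetamidophenyl in place of 3-chloro-5-methoxyphenyl on an aromatic carbon. Going by the values given here, only the step from compound 1 to compound 2 bears on this change, and it points in neither direction for a new aryl group. Compound 3 is therefore expected to lie between the two measured values, with a 3.9-fold higher number from compound 2 to compound 3 (0.60 log units; beyond the scatter). The estimate for compound 3 in this assay is 3000 nM, with a range from 600 nM to 15000 nM.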

Compound 3, half-maximal effective concentration: 139000 nM
Beside the measured number, compound 3's estimate is 46-fold (1.67 log units) below it; the measured number lies above the stated range.
By their numbers in this assay, from the lowest: compound 2; then compound 1; then compound 3.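

In this assay, 4-acetamidophenyl on this aromatic carbon gives a 180-fold higher number from compound 2 to compound 3 (2.26 log units; beyond the scatter) and an 8.2-fold higher number from compound 1 to compound 3 (0.91 log units; beyond the scatter). The aryl group here can therefore push the number up past that of 3-methylphenyl, not only bring it down, so the position is far from indifferent to which aryl group it carries. Nothing available accounts for this rise. As far as these compounds go, it remains open whether the acetamide itself or only its place on the phenyl ring matters, which 3-acetamidophenyl and 4-methoxyphenyl would help to separate.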